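Indazolyl for methylsulfonylphenyl: clearance outlook for compound 4

The source may report more compounds than this note shows. Statements on the series, on what has been measured and on what is new or still open speak of the compounds shown alone.

Three members of the series share one core and differ at a single aromatic carbon. Compound 1 `Nc1ccc(S(=O)(=O)N2CCN(c3ncc(C(O)(C(F)(F)F)C(F)(F)F)cc3Br)CC2)cn1` carries bromo there; in an ADME assay (liver) for metabolic stability, with Liver microsome (Homo sapiens) as the target, using microsomes and NADPH, with a stated time of 30 min, tested at 1 uM (on this read-out lower numbers stand for slow clearance and higher numbers for fast clearance), compound 1 gives < 14 mL.min-1.g-1, which is a limit of the assay and not a number (the limit of < 14 mL.min-1.g-1 in this assay, at which 1 of the 3 values shown sits). Compound 2 `Nc1ccc(S(=O)(=O)N2CCN(c3ncc(C(O)(C(F)(F)F)C(F)(F)F)cc3-c3cccc(F)c3)CC2)cn1` carries 3-fluorophenyl, and in this assay compound 2 gives 25 mL.min-1.g-1. Compound 3 `CS(=O)(=O)c1ccc(-c2cc(C(O)(C(F)(F)F)C(F)(F)F)cnc2N2CCN(S(=O)(=O)c3ccc(N)nc3)CC2)cc1` carries 4-(methylsulfonyl)phenyl, and in this assay compound 3 gives 32 mL.min-1.g-1. Of the two numbers shown compound 3 is the higher, but the gap a 1.3-fold higher number from compound 2 to compound 3 (0.11 log units; within the scatter) lies within the scatter, so compounds 2 and 3 cannot be told apart on this read-out. The two steps away from bromo, an at least 1.7-fold higher number from compound 1 to compound 2 (0.25 log units; that floor lies within the scatter) and an at least 2.2-fold higher number from compound 1 to compound 3 (0.35 log units; beyond the scatter), both run upward from the limit.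

Compound 4 `Nc1ccc(S(=O)(=O)N2CCN(c3ncc(C(O)(C(F)(F)F)C(F)(F)F)cc3-c3cccc4[nH]ncc34)CC2)cn1` exchanges the aryl group once more: 1H-indazol-4-yl in place of 4-(methylsulfonyl)phenyl on an aromatic carbon. Within the data shown here, the only measured step that bears on an aryl-for-aryl exchange is a 1.3-fold higher number from compound 2 to compound 3 (0.11 log units; within the scatter), within the scatter; the bromo-to-aryl steps do not match this kind of change. No shift beyond the scatter is therefore expected in this assay, and the estimated step of a 1.1-fold lower number from compound 3 to compound 4 (0.06 log units; within the scatter) is expected to stay within it. Compound 4 is expected at 28 mL.min-1.g-1, with a range from 14 mL.min-1.g-1 to 56 mL.min-1.g-1.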

Compound 4, intrinsic clearance in microsomes: 42 mL.min-1.g-1
Compound 4: middle estimate off by 1.5-fold (0.18 log units), on the low side, within the range that was stated.
By their numbers in this assay, from the lowest: compounds 2, 3 and 4 (each within the scatter of the next). At a limit, below all of these: compound 1.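

In this assay, 1H-indazol-4-yl, with its five-membered aromatic ring with 2 hetero atoms and 1 hydrogen-bond donor, is a further type of aryl group at this position, yet a 1.3-fold higher number from compound 3 to compound 4 (0.12 log units; within the scatter) and a 1.7-fold higher number from compound 2 to compound 4 (0.23 log units; within the scatter) both stay within the scatter, so the three aryl compounds cannot be told apart on this read-out. With an at least 3.0-fold higher number from compound 1 to compound 4 (0.47 log units; beyond the scatter), a second exchange of bromo for an aryl group clears the scatter, alongside an at least 2.2-fold higher number from compound 1 to compound 3 (0.35 log units; beyond the scatter), while the floor of an at least 1.7-fold higher number from compound 1 to compound 2 (0.25 log units; that floor lies within the scatter) goes against this pattern by staying within it. Compound 1 remains a limit of the assay and not a number: the limit of < 14 mL.min-1.g-1 in this assay, at which 1 of the 4 values shown sits.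

As far as these compounds go, whether a small non-aryl group at this position, such as an amine, a nitrile or a short alkyl chain, would read like bromo or like the aryl groups remains open, and the true size of each step away from bromo stays unknown. The compounds shown also do not tell whether an aryl group carrying a carboxylic acid or a basic amine would leave the range that the three aryl compounds occupy.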